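The compounds below may be only part of what the source reports. "The series", "measured", "known", "first", "only" and "open" are said of these compounds alone.

Compound 1 `CCN(CC)CCNc1n[n+]([O-])c2ccc(C)cc2[n+]1[O-]` — > 49000000 nM
Compound 2 `CCc1ccc2c(c1)[n+]([O-])c(NCCN(C)C)n[n+]2[O-]` — > 49000000 nM
Compound 3 `CCc1ccc2c(c1)[n+]([O-])c(NCCN1CCCCC1)n[n+]2[O-]` — 39000000 nM

In a physicochemical assay for solubility, in the presence of a further agent that is not named here (a higher number here means a more soluble compound, a lower number a less soluble compound), compound 1 gives > 49000000 nM, which is a limit of the assay and not a measured number. Compound 2 likewise gives > 49000000 nM, again a limit. Compound 2 therefore stands at the limit of > 49000000 nM in this assay, at which 2 of the 3 values shown sit, so its true solubility is known only as lying beyond that point. Compound 3 gives 39000000 nM in this assay, a measured number.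

Going by the values given here, the one measured step, an at least 1.2-fold lower number from compound 2 to compound 3 (0.09 log units; that floor lies within the scatter), changes the amine at the end of the chain and leaves the aromatic ring untouched, so it bears only loosely on the change to compound 4 `COCCOc1ccc2c(c1)[n+]([O-])c(NCCN(C)C)n[n+]2[O-]`, in which (2-methoxyethoxy in place of ethyl on an aromatic carbon). All three measured values sit at or close to the same high level, and the step of an at least 1.0-fold lower number from compound 2 to compound 4 (0.03 log units; that floor lies within the scatter) is expected to stay within the scatter. The estimate for compound 4 in this assay is 45000000 nM, with a range from 20000000 nM to 100000000 nM, and a fair chance that only a limit is reported.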

Compound 4, solubility: 43000000 nM
Compound 4: the middle estimate sits 1.0-fold (0.02 log units) above what was measured; the range from low to high includes it.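

Unlike the step to compound 3, this change touches the aromatic ring and leaves the amine at the end of the chain alone: in this assay, 2-methoxyethoxy in place of ethyl gives an at least 1.1-fold lower number from compound 2 to compound 4 (0.05 log units; that floor lies within the scatter). That figure is only a floor, so it shows no loss beyond the scatter at this ring carbon, yet it cannot exclude a larger one. The true size of the step stays unknown because compound 2 is known only as a limit: the limit of > 49000000 nM in this assay, at which 2 of the 4 values shown sit.

The compounds shown leave open how a carboxylic acid or a longer ether chain on this same aromatic carbon would read in this assay. They also leave open whether 2-methoxyethoxy gives a similar number when piperidin-1-yl ends the chain.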